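Working notes on a small aryl-substituent solubility series

The source may report more compounds than this note shows. Statements on the series, on what has been measured and on what is new or still open speak of the compounds shown alone.

Measured so far in a physicochemical assay for solubility, read by spectrophotometry, in phosphate buffer, with a stated time of 18 h, at pH 7.4; a lower number here means a less soluble compound, a higher number a more soluble compound:
compound 1 `CCc1ccc(-c2nc3c(c(C)nn3-c3ccccc3)c(-c3ccccc3O)c2C#N)cc1` gives 3100 nM
compound 2 `CCc1ccc(-c2nc3c(c(C)nn3-c3ccccc3)c(-c3ccccc3Cl)c2C#N)cc1` gives 1700 nM
compound 3 `CCc1ccc(-c2nc3c(c(C)nn3-c3ccccc3)c(-c3ccccc3F)c2C#N)cc1` gives 1700 nM

Compound 2 stands level with compound 3 at the digits shown, the two together the lowest of the three numbers; nearest is compound 3, with no change at the digits printed from compound 2 to compound 3 (within the scatter), furthest compound 1, with a 1.8-fold lower number from compound 1 to compound 2 (0.26 log units; within the scatter). The remaining step, a 1.8-fold lower number from compound 1 to compound 3 (0.26 log units; within the scatter), also lies within the scatter. Compound 4 `CCc1ccc(-c2nc3c(c(C)nn3-c3ccccc3)c(-c3ccccc3C(=O)OC)c2C#N)cc1` differs from compound 2 by methoxycarbonyl in place of chloro on an aromatic carbon. Among the measured compounds shown here, no measured step involves methoxycarbonyl; the closest comparisons, hydroxy to chloro and chloro to fluoro, each stayed within the scatter, so little movement is expected. The expected step is a 1.2-fold higher number from compound 2 to compound 4 (0.07 log units; within the scatter), with no direction claimed beyond the scatter. Compound 4 is estimated at 2000 nM, range 800 nM to 5000 nM.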

Compound 4, solubility: 17000 nM
Estimate against measurement, compound 4: 8.5-fold (0.93 log units) below; measured number outside the range, above it.
By their numbers in this assay, from the lowest: compounds 2, 3 and 1 (each within the scatter of the next); then compound 4.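

At this position, on an aromatic carbon ortho to a large group, hydroxy, chloro and fluoro had stayed within the scatter of one another in this assay, whereas methoxycarbonyl gives a 10-fold higher number from compound 2 to compound 4 (1.00 log units; beyond the scatter) and a 10-fold higher number from compound 3 to compound 4 (1.00 log units; beyond the scatter) and a 5.5-fold higher number from compound 1 to compound 4 (0.74 log units; beyond the scatter) as steps beyond it. The number at this position can therefore move well beyond the scatter, and the flat picture holds only among compounds 1, 2 and 3. Nothing available here explains the size of these steps.

As far as these compounds go, whether the steps belong to methoxycarbonyl alone remains open. A carboxylic acid, a primary amide or ethoxycarbonyl at the same place would test this.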